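The source may hold more compounds than are shown below. What is called first, only, known or untested is meant among the compounds shown, and "the series" means these compounds.

Measured so far:
compound 1 `O=C(Nc1ccc(Oc2ccnc3[nH]ccc23)cc1)c1cc2cccnc2n(-c2ccc(Cl)cc2)c1=O` – 290 nM
compound 2 `COc1ccc(-n2c(=O)c(C(=O)Nc3ccc(Oc4ccnc5[nH]ccc45)cc3)cc3cccnc32)cc1` – 930 nM

Going by the values given here, in a functional assay on A549 cells (Homo sapiens) for antiproliferative activity, read by MTT assay, with a stated time of 72 h (a higher number here means a weaker inhibitor, a lower number a stronger inhibitor), compound 2 gives the higher of the two numbers; the one step recorded, a 3.2-fold higher number from compound 1 to compound 2 (0.51 log units; beyond the scatter), places it above compound 1. Compound 3 `COc1ccc(-n2c(=O)c(C(=O)Nc3ccc(Oc4ccnc5[nH]ccc45)c(F)c3)cc3cccnc32)cc1` differs from compound 2 by fluoro in place of hydrogen on an aromatic carbon. Among the compounds with values here, no measured step involves this change, and the step from compound 1 to compound 2 concerns a different ring, so it gives no direct guide. Compound 3 is therefore expected near compound 2, with a 1.3-fold lower number from compound 2 to compound 3 (0.12 log units; within the scatter) inside the scatter, at an estimated 700 nM in the range 250 nM to 2000 nM.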

Compound 3, half-maximal inhibitory concentration: 610 nM
Estimate against measurement, compound 3: 1.1-fold (0.06 log units) above, and the stated range covers the measured number.
By their numbers in this assay, from the lowest: compound 1; then compounds 3 and 2 (each within the scatter of the next).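

Fluoro on an aromatic carbon of a six-membered aromatic ring of carbon only, ortho to a large group and meta to a large group, is the first change shown at this place. In this assay it gives a step within the scatter (a 1.5-fold lower number from compound 2 to compound 3 (0.18 log units; within the scatter)), so this position accepts a fluorine atom without a measurable change in activity. No available evidence bears on this result.

Still open, from the compounds shown here alone, is how an amine or a carboxylic acid would fare on this same carbon. Also open, going by these compounds, is whether fluoro would behave alike on compound 1.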